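Cytotoxicity of compound 3 expected to remain beyond the limit

The compounds below may be only part of what the source reports. "The series", "measured", "known", "first", "only" and "open" are said of these compounds alone.

Compound 2 `N#Cc1ccc(/C=C2\SC(=S)N(NS(=O)(=O)c3ccccc3)C2=O)cc1` stands only at a limit in a functional assay on HFF cells (Homo sapiens) for cytotoxicity; on this read-out lower numbers stand for stronger inhibition and higher numbers for weaker inhibition: in this assay compound 2 gives > 100000 nM, a limit of the assay and not a number. Compound 1 `COc1cccc(/C=C2\SC(=S)N(NS(=O)(=O)c3ccccc3)C2=O)c1` likewise gives > 100000 nM in this assay, again a limit. Going by the values given here, the one measured step, a step that the two limits leave unreadable from compound 1 to compound 2, is therefore not readable, and the only evidence is the limit of > 100000 nM in this assay, at which 2 of the 2 values shown sit. Compound 3 `O=C1/C(=C/c2ccc(Br)c(Br)c2)SC(=S)N1NS(=O)(=O)c1ccccc1` differs from compound 2 by 3,4-dibromophenyl in place of 4-cyanophenyl on a double-bonded chain carbon bound to a double-bonded ring carbon. No readable step bears on this change, so no step beyond the scatter is expected. Compound 3 is estimated at 100000 nM, within 30000 nM to 300000 nM, most likely reported again as a limit. The expected step of a number no higher from compound 2 to compound 3 (the limit leaves the size open) is estimated as none beyond the scatter.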

Compound 3, half-maximal inhibitory concentration: > 100000 nM
Compound 3: no number, only a limit; the forecaster's own chance of this, stated with the estimate: 75%; the middle value lies on the limit itself.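

No new step can be read, since compound 1, compound 2 and compound 3 are each known only as limits. The compounds shown leave open whether the groups exchanged on the double-bonded chain carbon make any difference in this assay.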